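Aryl Amide Variation on a Benzylsulfonamide Scaffold

The compounds below may be only part of what the source reports. "The series", "measured", "known", "first", "only" and "open" are said of these compounds alone.

Three compounds share one core and differ only in the aryl group on the carbonyl carbon. Compound 1 `O=C(NCc1ccc(CNS(=O)(=O)c2ccccc2)cc1)c1cccnc1` gives 10 nM in an assay on MDA-MB-231 cells for binding affinity to C-X-C chemokine receptor type 4 (Homo sapiens), read by immunofluorescence and microscopy, with stated times of 10 min and 30 min; a lower number here means that less compound is needed, a higher number that more compound is needed for the effect. Compound 2 `COc1ccccc1C(=O)NCc1ccc(CNS(=O)(=O)c2ccccc2)cc1` gives 1 nM, and compound 3 `O=C(NCc1ccc(CNS(=O)(=O)c2ccccc2)cc1)c1ccc([N+](=O)[O-])cc1` gives 100 nM. Compound 3 therefore stands highest of the three numbers: the step is a 10-fold higher number from compound 1 to compound 3 (1.00 log units; beyond the scatter) and a 100-fold higher number from compound 2 to compound 3 (2.00 log units; beyond the scatter), both beyond the scatter.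

Compound 4 `O=C(NCc1ccc(CNS(=O)(=O)c2ccccc2)cc1)c1c(Cl)cc(Cl)cc1Cl` has not yet been measured. It differs from compound 3 by a single change on the carbonyl carbon: 2,4,6-trichlorophenyl in place of 4-nitrophenyl on a carbonyl carbon. Among the compounds with values here, no measured step places a 2,4,6-trichlorophenyl group on this carbonyl carbon, so the comparison rests on how much the aryl group has already moved the number. The steps of a 10-fold lower number from compound 1 to compound 2 (1.00 log units; beyond the scatter) and a 10-fold higher number from compound 1 to compound 3 (1.00 log units; beyond the scatter) show that swapping this aryl group can move the number by a modest amount in either direction, and a 100-fold higher number from compound 2 to compound 3 (2.00 log units; beyond the scatter) shows a large span across the set.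

Given that the 4-nitrophenyl compound 3 sits at the top, compound 4 is estimated to fall somewhat lower, at 20 nM, with a range of 2 nM to 200 nM. Within the data shown here, this corresponds to an expected step of a 5.0-fold lower number from compound 3 to compound 4 (0.70 log units; beyond the scatter), and the uncertainty is wide because no measured compound carries this group.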

Compound 4, effective concentration (reported as EC, without a stated level of effect): 10 nM
Compound 4: the middle estimate sits 2.0-fold (0.30 log units) above what was measured, within the range that was stated.
By their numbers in this assay, from the lowest: compound 2; then compounds 1 and 4 (each within the scatter of the next); then compound 3.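

In this assay, a group with no hydrogen-bond acceptors on the carbonyl carbon can still give a number well under that of the 4-nitrophenyl group, since 2,4,6-trichlorophenyl in place of 4-nitrophenyl brings a 10-fold lower number from compound 3 to compound 4 (1.00 log units; beyond the scatter). The same group leaves a 10-fold higher number from compound 2 to compound 4 (1.00 log units; beyond the scatter), so the 2-methoxyphenyl of compound 2 keeps the lowest number of the set, while pyridin-3-yl and 2,4,6-trichlorophenyl show no change at the digits printed from compound 1 to compound 4 (within the scatter). No measurement offered here accounts for these differences.

The compounds shown leave open how an aliphatic group on this carbonyl carbon, such as a cyclohexyl ring or a butyl chain, would compare, and whether an amine or a carboxylic acid on the aryl ring would raise or lower the number. As far as these compounds go, how changes elsewhere in the shared core would move it also remains open.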